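The compounds below may be only part of what the source reports. "The series", "measured", "known", "first", "only" and "open" are said of these compounds alone.

Compound 2 `Cc1cn([C@@H]2O[C@H](CO)[C@@H](CO)[C@@H]2O)c(=O)[nH]c1=O` carries two hydroxymethyl groups on its shared core. In a functional assay on P388 cells (Mus musculus) for antiproliferative activity, with a stated time of 72 h (a higher number here means that more compound is needed for the effect, a lower number that less compound is needed), compound 2 gives > 100 uM, which is a limit of the assay and not a number. Compound 1 `Cc1cn([C@@H]2O[C@H](CO)[C@@H](CN=[N+]=[N-])[C@@H]2O)c(=O)[nH]c1=O` differs from compound 2 by azido in place of hydroxy on a saturated chain carbon bound to a saturated ring carbon. In this assay compound 1 gives > 100 uM, again a limit rather than a number. Compound 3 `Cc1cn([C@@H]2O[C@H](CO)[C@@H](CO)[C@H]2O)c(=O)[nH]c1=O` differs from compound 2 only in that (the two compounds have the same atoms and bonds and differ only in configuration as drawn: 1 of 4 stereo elements differ; a stereocentre at a saturated ring carbon is drawn S in compound 2 and R in compound 3). In this assay compound 3 gives > 100 uM, once more a limit. The step that the two limits leave unreadable from compound 2 to compound 1 and the step that the two limits leave unreadable from compound 2 to compound 3 cannot be sized because of the limit of > 100 uM in this assay, at which 3 of the 3 values shown sit; the difference between the cores of compound 2 and compound 3 is a matter of configuration alone, as the fact that compounds 2 and 3 differ only in the configuration as drawn shows.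

Compound 4 `Cc1cn([C@@H]2O[C@H](CO)[C@@H](CN=[N+]=[N-])[C@H]2O)c(=O)[nH]c1=O` stands to compound 3 as compound 1 stands to compound 2: azido in place of hydroxy on a saturated chain carbon bound to a saturated ring carbon. The place is described in the same words for both pairs, so this is the same change, made a second time on the core of compound 3. Since nothing in the measured trio rose above the limit, the same change on compound 3 is not expected to do otherwise. For compound 4 in this assay the estimated value is 150 uM, within an expected range from 50 uM to 500 uM. The expected step that the limit leaves unreadable from compound 3 to compound 4 from compound 3 to compound 4 is taken as essentially flat, resting on the unreadable step that the two limits leave unreadable from compound 2 to compound 1.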

Compound 4, concentration for half-maximal effect: > 100 uM
Compound 4: no number, only a limit; the forecaster's own chance of this, stated with the estimate: 85%; the middle value lies beyond the limit too.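

In this assay compound 4 gives > 100 uM, which is a limit of the assay and not a number. No new step can be read between compound 4 and either compound 3 or compound 1, because all the values sit at the same limit: the limit of > 100 uM in this assay, at which 4 of the 4 values shown sit. The compounds shown leave open how large the effect of azido in place of hydroxy, or of the configuration at the saturated ring carbon, would be in this assay.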